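A few compounds are considered here, and "the series" means these few. Any claim that something is new, unique, unknown or untested is made for them only; others in the source may bear on it.

Compound 1 `CCCNC(=O)Nc1cccc2c1CN(C)CC2c1ccccc1` returns only a limit of the assay in a functional assay on the whole organism for inhibition of sodium-dependent dopamine transporter (Mus musculus); on this read-out higher numbers stand for an effect only at larger amounts of compound and lower numbers for an effect already at smaller amounts: compound 1 reads > 120 mg/kg. For the measured compounds named here, compound 2 `CCCCNC(=O)Nc1cccc2c1CN(C)CC2c1ccccc1` is the single compound with a number in this assay, where compound 2 gives 69 mg/kg. Going by the values given here, the one measured step, an at least 1.7-fold lower number from compound 1 to compound 2 (0.24 log units; that floor lies within the scatter), changes the chain three bonds from the amide-type nitrogen, and its floor sits within the scatter; it departs from the limit (the limit of > 120 mg/kg in this assay, at which 1 of the 2 values shown sits), so its true size is open.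

Compound 3 `CCCCNC(=O)Nc1cccc2c1CN(C)CC2c1ccc(C)cc1` differs from compound 2 by methyl in place of hydrogen on an aromatic carbon. Among the compounds with values here, no measured step touches the aromatic ring, so the available data give no direction for this change. The expected step from compound 2 to compound 3 is therefore a 1.1-fold lower number from compound 2 to compound 3 (0.03 log units; within the scatter), that is, none beyond the scatter. Compound 3 is estimated at 65 mg/kg, with a range from 25 mg/kg to 150 mg/kg.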

Compound 3, dose for half-maximal effect: > 100 mg/kg
Compound 3 gave a limit, no number; the forecaster's own chance of this, stated with the estimate: 25%; at least 1.5-fold (0.18 log units) between middle value and limit.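

Compound 3 reads > 100 mg/kg in this assay, and this is a limit of the assay, not a number. For the compounds shown here, the phenyl to 4-methylphenyl change gives the first reading on the aromatic ring, and that reading is an at least 1.4-fold higher number from compound 2 to compound 3 (0.16 log units; that floor lies within the scatter); it shows no gain in this assay from methyl at this position, but it does not establish a loss beyond the scatter. On these data alone, the true size of the step remains open, since it departs from a limit: the limit of > 100 mg/kg in this assay, at which 1 of the 3 values shown sits.

Going by these compounds alone, with compound 1 and compound 3 both at limits, compound 2 remains the only number, so the chain step and the ring step cannot be compared in size. As far as these compounds go, whether a chlorine atom or a methoxy group at this ring position, or a pentyl chain in place of the butyl chain, would give a number remains open.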